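This account rests on a few compounds, and the source may have more. Where it says the series, first, only, none or still open, it means among the compounds named here.

Measured compounds:
- compound 3 `CC(C)C(NS(=O)(=O)c1cccc(Br)c1)C1=CC(=O)c2c(O)ccc(O)c2C1=O`: 790 nM
- compound 1 `Cc1ccc(S(=O)(=O)NC(C2=CC(=O)c3c(O)ccc(O)c3C2=O)C(C)C)cc1`: "not determined" (no result reported)
- compound 2 `CC(C)C(NS(=O)(=O)c1ccc(Br)cc1)C1=CC(=O)c2c(O)ccc(O)c2C1=O`: "not determined" (no result reported)

In a functional assay on HL-60 cells (Homo sapiens) for cytotoxicity, read by MTT assay (on this read-out higher numbers stand for weaker inhibition and lower numbers for stronger inhibition), compound 3 gives 790 nM. Among the compounds with values here, this is the only number in the set: for compound 1 the entry is "not determined" (no result reported), and for compound 2 it is "not determined" (no result reported), so neither offers a comparison. Within the data shown here, compound 3 therefore stands alone, and no step between measured compounds can be stated.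

Compound 4 `CCOC(=O)c1ccc(S(=O)(=O)NC(C2=CC(=O)c3c(O)ccc(O)c3C2=O)C(C)C)cc1` is the next compound in this assay. It differs from compound 3 in one place: 4-(ethoxycarbonyl)phenyl in place of 3-bromophenyl on a sulfonyl sulfur. The 3-bromophenyl on the sulfonyl sulfur is replaced by 4-(ethoxycarbonyl)phenyl, the sulfonyl sulfur keeping the sulfonamide nitrogen as its other neighbour. Among the measured compounds shown here, the three compounds give no earlier example of such a change at this position.

With compound 3 as the only reference, a modest step is expected, a 1.5-fold higher number from compound 3 to compound 4 (0.18 log units; within the scatter), leaning towards weaker inhibition, though a result within the scatter would not surprise. Compound 4 is expected to give about 1200 nM, with a range from 400 nM to 4000 nM.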

Compound 4, half-maximal inhibitory concentration: 150 nM
The estimate for compound 4 lay 8.0-fold (0.90 log units) above the measured number; measured number below the stated range.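

Within the data shown here, replacing 3-bromophenyl with 4-(ethoxycarbonyl)phenyl on the sulfonyl sulfur gives a 5.3-fold lower number from compound 3 to compound 4 (0.72 log units; beyond the scatter) in this assay, which shows for the first time that the group at this position bears on the read-out. The entering group is the larger of the two, with 11 heavy atoms against 7 and 2 hydrogen-bond acceptors against 0, yet the number falls rather than rises. No supporting measurement accounts for this step.

Both the substituent and its place on the ring change in this single step, so the contribution of each remains unresolved, and steps involving compounds 1 and 2 cannot be read without results for them. From the compounds shown here alone, it also remains open whether a carboxylic acid or a methyl ester in place of the ethyl ester would keep the lower number.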